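This account rests on a few compounds, and the source may have more. Where it says the series, first, only, none or still open, it means among the compounds named here.

Measured compounds:
Compound 1, `COc1cc2ncnc(Nc3cccc(Br)c3)c2cc1OCCCCC(=O)Nc1ccc(S(N)(=O)=O)cc1`: in a functional assay on A-431 cells (Homo sapiens) for antiproliferative activity, read by MTT assay, with a stated time of 72 h (on this read-out lower numbers stand for stronger inhibition and higher numbers for weaker inhibition), compound 1 gives 9750 nM.
Compound 2, `COc1cc2ncnc(Nc3ccc(F)cc3)c2cc1OCCCCC(=O)Nc1ccc(S(N)(=O)=O)cc1`: compound 2 gives 18600 nM.
Compound 3, `COc1cc2ncnc(Nc3ccc(Cl)cc3)c2cc1OCCCCC(=O)Nc1ccc(S(N)(=O)=O)cc1`: compound 3 gives 7120 nM.

Compound 3 holds the lowest of the three numbers. Its distance to compound 1 is small, a 1.4-fold lower number from compound 1 to compound 3 (0.14 log units; within the scatter), and lies within the scatter, so the two cannot be ordered. The step of a 2.6-fold lower number from compound 2 to compound 3 (0.42 log units; beyond the scatter) is the only one of the set that lies beyond the scatter, and even that one is modest. The remaining pair, a 1.9-fold higher number from compound 1 to compound 2 (0.28 log units; within the scatter), again stays within the scatter.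

Compound 4, `COc1ccc(Nc2ncnc3cc(OC)c(OCCCCC(=O)Nc4ccc(S(N)(=O)=O)cc4)cc23)cc1`, differs from compound 3 in one place: methoxy in place of chloro on an aromatic carbon. Within the data shown here, no measured step swaps a halogen for methoxy on this ring, so the expectation rests on the halogen comparisons alone. Those show that exchanging one group for another on the aniline ring moves this assay by at most a modest amount, as in a 2.6-fold lower number from compound 2 to compound 3 (0.42 log units; beyond the scatter), or not measurably, as in a 1.4-fold lower number from compound 1 to compound 3 (0.14 log units; within the scatter). A change of this kind is therefore expected to shift the number only a little, most likely upward, giving an estimated step of a 1.7-fold higher number from compound 3 to compound 4 (0.23 log units; within the scatter). For compound 4 the estimated value is 12000 nM, with a range from 4000 nM to 40000 nM.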

Compound 4, half-maximal inhibitory concentration: 14700 nM
Estimate against measurement, compound 4: 1.2-fold (0.09 log units) below; measured number inside the range.
By their numbers in this assay, from the lowest: compounds 3, 1, 4 and 2 (each within the scatter of the next, the first and the last beyond it).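

In this assay, compound 2 and compound 3 carried only fluoro and chloro at this position, para to a large group, and compound 4 adds a methoxy group with its extra hydrogen-bond acceptor: methoxy in place of chloro gives a 2.1-fold higher number from compound 3 to compound 4 (0.31 log units; beyond the scatter), a modest step. Methoxy and fluoro cannot be told apart at this position, with a 1.3-fold lower number from compound 2 to compound 4 (0.10 log units; within the scatter), so chloro is the one group of the three that stands apart from both others, though only modestly. The comparison with the 3-bromophenyl group gives a 1.5-fold higher number from compound 1 to compound 4 (0.18 log units; within the scatter), so 4-methoxyphenyl and 3-bromophenyl cannot be separated either, and the widest gap in the set remains a 2.6-fold lower number from compound 2 to compound 3 (0.42 log units; beyond the scatter).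

The compounds shown come with no measurement that could explain why chloro stands apart from fluoro and methoxy at this position. As far as these compounds go, it remains open whether an amine, a carboxylic acid or a trifluoromethyl group at this position would move the number further than these groups do, and what a longer chain in the amide-bearing arm would do to it.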